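Side-chain variation on the shared core: microsomal half-life

The source may report more compounds than this note shows. Statements on the series, on what has been measured and on what is new or still open speak of the compounds shown alone.

Measured in an ADME assay on microsomes from liver (Homo sapiens) for metabolic stability; a lower number here means that the compound disappears faster, a higher number that the compound lasts longer:
compound 1 `CC(C)NC(=O)CC(c1ccc(-c2ccc3cccc(F)c3c2)[nH]c1=O)C(C)C` gives 0.32 h
compound 2 `CC(C)C(Nc1nccs1)c1ccc(-c2ccc3cccc(F)c3c2)[nH]c1=O` gives 0.17 h
compound 3 `Cc1nc(C(c2ccc(-c3ccc4cccc(F)c4c3)[nH]c2=O)C(C)C)[nH]c1C` gives 0.268 h

Compound 3 holds the second highest of the three numbers in this assay. Its nearest neighbour is compound 1, with the step of a 1.2-fold lower number from compound 1 to compound 3 (0.08 log units; within the scatter); furthest is compound 2, with the step of a 1.6-fold higher number from compound 2 to compound 3 (0.20 log units; within the scatter). The third measured step, a 1.9-fold lower number from compound 1 to compound 2 (0.27 log units; within the scatter), is likewise within the scatter. All three steps change the group on the saturated chain carbon bound to an aromatic carbon and a saturated chain carbon, while the rest of the shared core is kept.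

Compound 4 `CC(C)C(Cc1nnc[nH]1)c1ccc(-c2ccc3cccc(F)c3c2)[nH]c1=O` is the next variation at that same place: (4H-1,2,4-triazol-3-yl)methyl in place of 4,5-dimethyl-1H-imidazol-2-yl on a saturated chain carbon bound to an aromatic carbon and a saturated chain carbon

Because every measured exchange at this position, a 1.9-fold lower number from compound 1 to compound 2 (0.27 log units; within the scatter), a 1.2-fold lower number from compound 1 to compound 3 (0.08 log units; within the scatter) and a 1.6-fold higher number from compound 2 to compound 3 (0.20 log units; within the scatter), stayed within the scatter, no step beyond the scatter is expected here either, in either direction. Compound 4 is therefore expected to give 0.25 h in this assay, within a range of 0.12 h to 0.5 h. The step of a 1.1-fold lower number from compound 3 to compound 4 (0.03 log units; within the scatter) is thus estimated to remain within the scatter.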

Compound 4, half-life: 0.307 h
Compound 4: the middle estimate sits 1.2-fold (0.09 log units) below what was measured; the range from low to high includes it.
By their numbers in this assay, from the lowest: compounds 2, 3, 4 and 1 (each within the scatter of the next).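

In this assay, compound 4 brings a five-membered aromatic ring with 3 hetero atoms and 2 hydrogen-bond acceptors to this position, and the steps of a 1.1-fold higher number from compound 3 to compound 4 (0.06 log units; within the scatter) and a 1.8-fold higher number from compound 2 to compound 4 (0.26 log units; within the scatter) both stay within the scatter. The narrowest exchange so far is read on the same chain, where the carbon chain is kept, the end group alone is exchanged, 4H-1,2,4-triazol-3-yl replacing isopropylcarbamoyl, and the step is a 1.0-fold lower number from compound 1 to compound 4 (0.02 log units; within the scatter), so neither an amide end group nor an aromatic ring at that chain end separates from the other in this assay. With four different groups now in place and no step beyond the scatter, the position has yet to show any sensitivity in this read-out, and nothing available accounts for that result.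

Still open, on these data alone, is whether a carboxylic acid or a primary amine on the saturated chain carbon, or a longer chain carrying the 4H-1,2,4-triazol-3-yl ring, would give a step beyond the scatter. All four compounds also keep the shared core, so whether this insensitivity would hold with a different core remains unanswered.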